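The compounds below may be only part of what the source reports. "The series", "measured", "known", "first", "only" and "open" are said of these compounds alone.

Measured compounds in an assay on HEK293 cells for agonist activity at transient receptor potential cation channel subfamily M member 8 (Homo sapiens), read by fluorescence and calcium flux, with a stated time of 15 min; on this read-out higher numbers stand for an effect only at larger amounts of compound and lower numbers for an effect already at smaller amounts:
compound 1 `COc1ccc2oc(C(=O)N(Cc3cccs3)c3ccn[nH]3)cc2c1` gives 1.1 nM
compound 2 `Cc1ccc(OCC(=O)N(Cc2cccs2)c2ccnn2C)cc1` gives 422 nM
compound 3 `CCN(Cc1cccs1)C(=O)c1cc2cc(C)ccc2s1` gives 1600 nM

Compound 2 holds the second highest of the three numbers. Its nearest neighbour is compound 3, which sits at a higher number, and the gap between the two lies beyond the scatter; compound 1 sits at a far lower number, and that gap is wider still. Among the compounds with values here, no pair among the measured compounds differs in only one place, so no single-change step is available as a guide.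

Compound 4 `CCCN(Cc1cccs1)C(=O)COc1ccc(C)cc1` has not been measured. Against compound 2 the change is propyl in place of 1-methyl-1H-pyrazol-5-yl on an amide-type nitrogen. Within the data shown here, the only measured compound that carries a short chain rather than a ring on the amide-type nitrogen is compound 3, which gives 1600 nM in this assay, but it differs from compound 2 in more than one place, so it can only hint at direction. The expectation is a step toward a higher number in this assay, beyond the scatter.

Compound 4 is expected to give 1500 nM, within a range of 400 nM to 6000 nM. The estimate implies a step of a 3.6-fold higher number from compound 2 to compound 4 (0.55 log units; beyond the scatter), which is expected to exceed the scatter.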

Compound 4, half-maximal effective concentration: 40 nM
Compound 4: middle estimate off by 38-fold (1.57 log units), on the high side; measured number outside the range, below it.
By their numbers in this assay, from the lowest: compound 1; then compound 4; then compound 2; then compound 3.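

In this assay, the series now has its first step that changes one place only: propyl in place of 1-methyl-1H-pyrazol-5-yl on an amide-type nitrogen gives an 11-fold lower number from compound 2 to compound 4 (1.02 log units; beyond the scatter). With the rest of compound 2 held fixed, a five-membered aromatic ring is therefore not needed on this nitrogen for a lower number, and a chain with no ring and no hydrogen-bond acceptors gives a lower number than that ring does. No measurement shown here explains this step.

Whether propyl is special remains open, since the compounds shown do not reveal how a butyl chain or a cyclopropyl ring would behave on this nitrogen. Also open, on these data alone, is whether the same swap would shift the number in the same direction on the core of compound 1.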